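Nitrile position on the benzyl group of compound 1

This account rests on a few compounds, and the source may have more. Where it says the series, first, only, none or still open, it means among the compounds named here.

Within the data shown here, compound 1 `CSCC[C@H](NC(=O)c1ccc(NCc2cncn2Cc2ccccc2C#N)cc1-c1ccccc1)C(=O)O` stands only at a limit on the numbers so far. In a functional assay on NIH3T3 cells (Mus musculus) (a lower number here means that less compound is needed, a higher number that more compound is needed for the effect), compound 1 gives > 10 uM, which is a limit of the assay and not a number. Compound 2 `COC(=O)[C@H](CCSC)NC(=O)c1ccc(NCc2cncn2Cc2ccccc2C)cc1-c1ccccc1` likewise returns only a limit, > 10 uM. Among the measured compounds shown here, both values rest at the limit of > 10 uM in this assay, at which 2 of the 2 values shown sit, so no step between measured compounds can be sized. Compound 3 `CSCC[C@H](NC(=O)c1ccc(NCc2cncn2Cc2cccc(C#N)c2)cc1-c1ccccc1)C(=O)O` differs from compound 1 by 3-cyanophenyl in place of 2-cyanophenyl on a saturated chain carbon bound to an aromatic nitrogen. With the known values resting at the same limit, the step that the limit leaves unreadable from compound 1 to compound 3 is expected to be none beyond the scatter. Compound 3 is expected near 15 uM, within 5 uM to 50 uM, and most likely reported again as a limit.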

Compound 3, concentration for half-maximal effect: > 10 uM
Compound 3 gave a limit, no number; the forecaster's own chance of this, stated with the estimate: 75%; the middle value is on the limit's open side.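

In this assay compound 3 gives > 10 uM, a limit and not a number. No step between compound 1 and compound 3 can be read: the limit of > 10 uM in this assay, at which 3 of the 3 values shown sit.

The compounds shown leave open whether 2-cyanophenyl and 3-cyanophenyl differ at all in this read-out.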